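The compounds below may be only part of what the source reports. "The series", "measured", "known", "first", "only" and "open" are said of these compounds alone.

Measured so far in an ADME assay on HEK293 cells (Homo sapiens) for cytotoxicity, with a stated time of 72 h (a lower number here means that less compound is needed, a higher number that more compound is needed for the effect), each value being a limit and not a number:

- Compound 1 `C=C[C@@](C)(/C=C/c1ccc(OS(=O)(=O)C(F)(F)F)cc1)CCC=C(C)C`: > 36600 nM
- Compound 2 `C=C[C@@](C)(/C=C/c1ccc(OS(=O)(=O)c2ccc(C)cc2)cc1)CCC=C(C)C`: > 36600 nM
- Compound 3 `C=C[C@@](C)(/C=C/c1ccc(O)cc1)CCC1OC1(C)C`: > 36600 nM

Compound 3 therefore has no readable position in this assay, only its limit of > 36600 nM. It shares this standing with the other two compounds, and the record shows (the limit of > 36600 nM in this assay, at which 3 of the 3 values shown sit).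

The next structure, compound 4 `C=C[C@@](C)(/C=C/c1ccc(O)cc1)CCC=O`, has formyl in place of 3,3-dimethyloxiran-2-yl on a saturated chain carbon, three bonds along the chain from two double-bonded chain carbons.

Among the measured compounds shown here, the only measured step offers little guidance. It is a step that the two limits leave unreadable from compound 1 to compound 2, and it concerns 4-methylphenyl in place of trifluoromethyl on a sulfonyl sulfur, a different change from this one with no readable size. For the measured compounds named here, no measured step therefore gives a size or direction for the change to formyl. Going by the values given here, with the limit of > 36600 nM in this assay, at which 3 of the 3 values shown sit, as the sole evidence, no step beyond the scatter is expected, and compound 4 will most likely also be reported as a limit. The expected change is an at least 1.0-fold lower number from compound 3 to compound 4 (0.00 log units; that floor lies within the scatter), a cautious figure given that no number has yet been measured. For compound 4 the estimate is 36000 nM, with an expected range from 15000 nM to 60000 nM.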

Compound 4, half-maximal effective concentration: > 36600 nM
Compound 4: only a limit was reported; the forecaster's own chance of this, stated with the estimate: 75%; middle value at least 1.0-fold (0.00 log units) from the limit.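

In this assay compound 4 gives > 36600 nM, which is a limit and not a number. With compound 3 also reported only as a limit, no step can be read between the two. The compounds shown leave open whether any change to the shared core would give a readable number in this assay, as all of them stand at one value: the limit of > 36600 nM in this assay, at which 4 of the 4 values shown sit.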